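The source may hold more compounds than are shown below. What is called first, only, known or untested is meant among the compounds shown, and "the series" means these compounds.

Measured in a functional assay on A-375 cells (Homo sapiens) for inhibition, read by MTT assay, with a stated time of 120 h; a higher number here means a weaker inhibitor, a lower number a stronger inhibitor:
compound 1 `O=C(/C=C/c1ccc(NC(=O)Nc2ccc(Cl)c(C(F)(F)F)c2)cc1)NC1CCC1`: 15400 nM
compound 2 `CNC(=O)/C(C)=C/c1ccc(NC(=O)Nc2ccc(Cl)c(C(F)(F)F)c2)cc1`: > 50000 nM
compound 3 `CC(NC(=O)CCc1ccc(NC(=O)Nc2ccc(Cl)c(C(F)(F)F)c2)cc1)c1ccccc1`: > 50000 nM (a limit)

Compound 3 gives > 50000 nM, which is a limit and not a number. That places compound 3 at the limit of > 50000 nM in this assay, at which 2 of the 3 values shown sit.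

Compound 4 `O=C(CCc1ccc(NC(=O)Nc2ccc(Cl)c(C(F)(F)F)c2)cc1)NC1CCC1` differs from compound 3 in one place: cyclobutyl in place of 1-phenylethyl on an amide-type nitrogen. Within the data shown here, no measured step isolates this change. The nearest evidence is an at least 3.2-fold higher number from compound 1 to compound 2 (0.51 log units; beyond the scatter), where 2-(methylcarbamoyl)prop-1-en-1-yl stands in place of 2-(cyclobutylcarbamoyl)ethenyl. That step alters more than the cyclobutyl group, so it is only a loose guide. Among the measured compounds shown here, compound 1 is the only compound here with a true number, and it carries a cyclobutyl group on its amide-type nitrogen, giving 15400 nM. A modest move towards a lower number is therefore expected, though the result could again be a limit. The expected change is an at least 2.0-fold lower number from compound 3 to compound 4 (0.31 log units; beyond the scatter). For compound 4 the estimated value is 24000 nM, with an expected range from 9000 nM to 50000 nM.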

Compound 4, half-maximal inhibitory concentration: > 50000 nM
Compound 4 was reported as a limit; the forecaster's own chance of this, stated with the estimate: 35%; middle value at least 2.0-fold (0.31 log units) away from the limit.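

In this assay, keeping the cyclobutylcarbamoyl end while replacing the ethenyl link with an ethyl link gives an at least 3.2-fold higher number from compound 1 to compound 4 (0.51 log units; beyond the scatter). The cyclobutyl group alone therefore does not secure a measurable value: among the compounds shown, a true number appears only in compound 1, where the cyclobutyl group and the ethenyl link occur together. The steps to compound 4 from compound 3 and from compound 2 cannot be read, because both ends of each step are limits, and compound 4 is one more such limit: the limit of > 50000 nM in this assay, at which 3 of the 4 values shown sit.

As far as these compounds go, it remains open whether the 1-phenylethyl group would give a true number on the ethenyl link, which would show how much the cyclobutyl group itself contributes. Also open, from the compounds shown here alone, is how an amine or a carboxylic acid would read in place of the cyclobutylcarbamoyl end with that link kept.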